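This account rests on a few compounds, and the source may have more. Where it says the series, first, only, none or still open, it means among the compounds named here.

Compound 1 `Cc1ccnc(/C(N)=N/NC(=S)N2CCCCCC2)c1`: 75.9% in a functional assay on MCF7 cells (Homo sapiens) for cytotoxicity, read by MTT assay, with a stated time of 72 h, tested at 30 uM; on this read-out lower numbers stand for less inhibition of growth and higher numbers for more inhibition of growth at the one concentration tested; compound 2 `N/C(=N\NC(=S)N1CCN(c2ccccn2)CC1)c1ccc(F)cn1`: 58.6%; compound 3 `N/C(=N\NC(=S)N1CCCCCC1)c1ccccn1`: 76.5%.

Among these three numbers compound 2 stands lowest, with compound 1 the nearest and compound 3 the furthest, both beyond the scatter. Compound 4 `N/C(=N\NC(=S)N1CCN(c2ccccn2)CC1)c1ccccn1` has not yet been measured. The change from compound 2 to compound 4 is hydrogen in place of fluoro on an aromatic carbon. For the measured compounds named here, only one measured step is available for comparison: a number 0.6 percentage points higher from compound 1 to compound 3 (within the scatter), which is also the loss of a small group from an aromatic carbon of the shared core and stayed within the scatter. That step concerns methyl, not fluoro, so it bears on the present change only loosely. The expectation for compound 4 is therefore a step of about a number 2.4 percentage points higher from compound 2 to compound 4 (within the scatter), with no clear direction beyond the scatter. Compound 4 is estimated at 61%, between 46% and 76%.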

Compound 4, percent growth inhibition at one concentration: 65.3%
The estimate for compound 4 lay 4.3 percentage points below the measured number; low and high end bracket the measured number.
By their numbers in this assay, from the lowest: compounds 2 and 4 (each within the scatter of the next); then compounds 1 and 3 (each within the scatter of the next).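

In this assay the step is a number 6.7 percentage points higher from compound 2 to compound 4 (within the scatter) when 5-fluoropyridin-2-yl gives way to pyridin-2-yl, so fluoro at this position, para to a large group, does not shift growth inhibition beyond the usual scatter. Together with a number 0.6 percentage points higher from compound 1 to compound 3 (within the scatter) for the loss of methyl elsewhere on the aromatic ring, this makes two small-group removals that both stay within the scatter. No measured evidence is available to account for this step.

From the compounds shown here alone, whether an amine, a methoxy group or a carboxylic acid at this position would shift the number beyond the scatter remains open.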